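This account rests on a few compounds, and the source may have more. Where it says the series, first, only, none or still open, it means among the compounds named here.

Compound 1 `CC(C)c1cc2ccccn2c1S(=O)(=O)c1ccc(OCCCNC(C)(C)C)cc1` and compound 2 `CCCCN(CCCC)CCCOc1ccc(S(=O)(=O)c2c(C(C)C)cc3ccccn23)cc1` share one core and differ in a single group. In a functional assay (aorta) for inhibition, with Rattus norvegicus as the target (on this read-out lower numbers stand for stronger inhibition and higher numbers for weaker inhibition), compound 1 gives 32.9 nM, and compound 2 gives 13.3 nM. The change between them is dibutylamino in place of (tert-butyl)amino on a saturated chain carbon, three bonds along the chain from an oxygen on an aromatic ring, and it made a step of a 2.5-fold lower number from compound 1 to compound 2 (0.39 log units; beyond the scatter).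

Compound 3 `CC(C)c1nn2ccccc2c1S(=O)(=O)c1ccc(OCCCNC(C)(C)C)cc1` carries the same chain as compound 1 on a different core; how the two cores differ is not broken down here. In this assay compound 3 gives 168 nM, the highest number of the three measured compounds.

Compound 4 `CCCCN(CCCC)CCCOc1ccc(S(=O)(=O)c2c(C(C)C)nn3ccccc23)cc1` is not yet measured. It stands to compound 3 as compound 2 stands to compound 1, through the same change, (dibutylamino in place of (tert-butyl)amino on a saturated chain carbon, three bonds along the chain from an oxygen on an aromatic ring), at the same place. Among the measured compounds shown here, the expectation for compound 4 rests on the single measured instance of this change, the step from compound 1 to compound 2, and on the value of compound 3 as its starting point. Compound 4 is therefore expected to move by about a 2.5-fold lower number from compound 3 to compound 4 (0.40 log units; beyond the scatter) in this assay, and its value is estimated at 67 nM, with a likely range from 35 nM to 130 nM.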

Compound 4, half-maximal inhibitory concentration: 31.1 nM
Beside the measured number, compound 4's estimate is 2.2-fold (0.33 log units) above it; the measured number lies below the stated range.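

In this assay the exchange of (tert-butyl)amino for dibutylamino also lowered the number on the core of compound 3, with a 5.4-fold lower number from compound 3 to compound 4 (0.73 log units; beyond the scatter), so the direction of the step held on both cores shown. Set side by side, the two steps cannot be told apart in size: the same change on two cores in this assay, a 2.5-fold lower number (0.39 log units; beyond the scatter) from compound 1 to compound 2 and a 5.4-fold lower number (0.73 log units; beyond the scatter) from compound 3 to compound 4, 2.2-fold (0.34 log units) apart, within the scatter of two such steps. Among the compounds shown here, with only two pairs, this shows that the change carried over from one core to the other in direction and, within the scatter, in size, but it does not show a real difference in size on the two cores, nor that the change would behave alike on any further core.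

The compounds shown leave open what other amines at this place, such as diethylamino or piperidine, would give on either core. They also leave open whether the step would persist with a longer chain leading from the oxygen on the aromatic ring to the amine.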